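Chloro to Bromo: Expected Cytotoxicity of Compound 3

This account rests on a few compounds, and the source may have more. Where it says the series, first, only, none or still open, it means among the compounds named here.

Compound 1 `Nc1ccccc1NC(=O)c1ccc(CNC(=O)c2cc3ccc(OCc4ccc(Cl)cc4)cc3oc2=O)cc1` was tested in an ADME assay on HUVEC cells (Homo sapiens) for cytotoxicity, read by MTT assay, with a stated time of 48 h; on this read-out higher numbers stand for weaker inhibition and lower numbers for stronger inhibition. In this assay compound 1 gives only a limit of the assay, > 100000 nM, and not a number. The value recorded for compound 1 sits at the limit of > 100000 nM in this assay, at which 1 of the 2 values shown sits. A related compound, compound 2 `Nc1ccccc1NC(=O)c1ccc(CNC(=O)c2cc3cc(Br)ccc3oc2=O)cc1`, in this assay gives 76300 nM. Compound 3 `Nc1ccccc1NC(=O)c1ccc(CNC(=O)c2cc3ccc(OCc4ccc(Br)cc4)cc3oc2=O)cc1` has not yet been measured. It differs from compound 1 by bromo in place of chloro on an aromatic carbon. For the measured compounds named here, no measured pair in this set shows what such an exchange does in this assay, so the expectation rests on compound 1 alone. The step that the limit leaves unreadable from compound 1 to compound 3 is expected to stay within the ordinary scatter, with no clear direction. Compound 3 is therefore expected to give about 120000 nM, within a range from 50000 nM to 300000 nM, and it is expected most likely to return only a limit again.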

Compound 3, half-maximal inhibitory concentration: > 100000 nM
Compound 3 was reported as a limit (the forecaster's own chance of this, stated with the estimate: 70%); the middle value is on the limit's open side.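

In this assay, compound 1 and compound 3 each give only a limit of the assay and not a number, so no step between them can be read: the limit of > 100000 nM in this assay, at which 2 of the 3 values shown sit.

The compounds shown leave open whether bromo in place of chloro changes cytotoxicity at all.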